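Swapping the indanylamino group for a thienylmethyl amine

This account rests on a few compounds, and the source may have more. Where it says the series, first, only, none or still open, it means among the compounds named here.

Measured compounds:
compound 1, `O[C@H]1Cc2ccccc2C1NC1CCN(CCCc2c[nH]c3ccc(-n4cnnc4)cc23)CC1`, 300 nM
compound 2, `CC(C)=CCCN(C)C1CCN(CCCc2c[nH]c3ccc(-n4cnnc4)cc23)CC1`, 24 nM
compound 3, `c1ccc2c(c1)CCC2NC1CCN(CCCc2c[nH]c3ccc(-n4cnnc4)cc23)CC1`, 280 nM

In an assay on CHO cells for displacement of a labelled ligand from 5-hydroxytryptamine receptor 1B (Homo sapiens) (a higher number here means a weaker inhibitor, a lower number a stronger inhibitor), compound 3 stands second highest of the three, with compound 1 within the scatter of it and compound 2 far below, as a 12-fold higher number from compound 2 to compound 3 (1.07 log units; beyond the scatter) shows. Compound 4 `CN(Cc1ccsc1)C1CCN(CCCc2c[nH]c3ccc(-n4cnnc4)cc23)CC1` differs from compound 3 by methyl((thiophen-3-yl)methyl)amino in place of (2,3-dihydro-1H-inden-1-yl)amino on a saturated ring carbon. Within the data shown here, the one step that bears on this is a 12-fold higher number from compound 2 to compound 3 (1.07 log units; beyond the scatter), where an amino group bearing a methyl gave way to the indanylamino group; compound 4 brings back an amino group bearing a methyl, though with a different second substituent. A lower number is therefore expected for compound 4, roughly a 6.2-fold lower number from compound 3 to compound 4 (0.79 log units; beyond the scatter). Compound 4 is estimated at 45 nM, with a range from 12 nM to 160 nM.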

Compound 4, half-maximal inhibitory concentration: 35 nM
Estimate against measurement, compound 4: 1.3-fold (0.11 log units) above, and the stated range covers the measured number.
By their numbers in this assay, from the lowest: compounds 2 and 4 (each within the scatter of the next); then compounds 3 and 1 (each within the scatter of the next).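

In this assay, methyl((thiophen-3-yl)methyl)amino on this saturated ring carbon gives an 8.0-fold lower number from compound 3 to compound 4 (0.90 log units; beyond the scatter) and an 8.6-fold lower number from compound 1 to compound 4 (0.93 log units; beyond the scatter), so the lower numbers are not confined to the open chain of compound 2. Replacing that chain's 3-methylbut-2-en-1-yl end with thiophen-3-yl gives a 1.5-fold higher number from compound 2 to compound 4 (0.16 log units; within the scatter), so at this position the aromatic ring and the chain end cannot be told apart. No available evidence explains these differences.

Whether the methyl on the amine nitrogen or the loss of the (2,3-dihydro-1H-inden-1-yl) group accounts for the drop remains open. From the compounds shown here alone, it is also open whether a phenyl or thiophen-2-yl group could stand in for thiophen-3-yl.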